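The compounds below may be only part of what the source reports. "The series", "measured", "known", "first", "only" and "open" are said of these compounds alone.

Working notes on the series. Going by the values given here, compound 1 `CN(C[C@H]1Cc2c(cccc2N2CCN(Cc3ccccn3)CC2)CN1)[C@H]1CCCc2cccnc21` gives 4.47 nM in a functional assay on CCRF-CEM cells for antagonist activity at C-X-C chemokine receptor type 4 (Homo sapiens), read by calcium flux, with stated times of 25 min and 90 s (a higher number here means a weaker inhibitor, a lower number a stronger inhibitor), and so shows the lowest of the two numbers known so far. Compound 2 `CCCN(C[C@H]1Cc2c(cccc2N2CCNCC2)CN1)[C@H]1CCCc2cccnc21` gives 32.2 nM in this assay, a higher number than compound 1 by a step beyond the scatter; the two compounds differ in more than one place, so the comparison says only what the two values show.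

Compound 3 `CN(C[C@H]1Cc2c(cccc2N2CCN(c3ncccn3)CC2)CN1)[C@H]1CCCc2cccnc21` has not been measured. It differs from compound 1 in one place: pyrimidin-2-yl in place of (pyridin-2-yl)methyl on an amine nitrogen in a ring. Among the compounds with values here, no measured pair in this set reports the effect of such a change on its own, so the direction is uncertain. Pyrimidin-2-yl sits directly on the amine nitrogen in the ring, whereas (pyridin-2-yl)methyl places the aromatic ring one atom further out, and a modest weakening is expected, the step from compound 1 to compound 3 estimated at a 2.2-fold higher number from compound 1 to compound 3 (0.35 log units; beyond the scatter). Compound 3 is expected to give about 10 nM in this assay, with a range from 3 nM to 40 nM.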

Compound 3, half-maximal inhibitory concentration: 30.7 nM
The estimate for compound 3 lay 3.1-fold (0.49 log units) below the measured number, and the stated range covers the measured number.
By their numbers in this assay, from the lowest: compound 1; then compounds 3 and 2 (each within the scatter of the next).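

In this assay, the first step read at a single place shows that the group on this amine nitrogen of the six-membered ring is not interchangeable: pyrimidin-2-yl in place of (pyridin-2-yl)methyl gives a 6.9-fold higher number from compound 1 to compound 3 (0.84 log units; beyond the scatter), a step beyond the scatter. The change alters two things at once, since the methyl link goes and the aromatic ring carries 2 hetero atoms instead of 1, so this step shows only their combined effect. No supporting measurement bears on why the number rises.

The compounds shown leave open how much of the step belongs to the link and how much to the ring. A pyridin-2-yl group set directly on this nitrogen, or a (pyrimidin-2-yl)methyl group, would separate the two.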